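Replacing the acetamido group on the shared core

The compounds below may be only part of what the source reports. "The series", "measured", "known", "first", "only" and "open" are said of these compounds alone.

Compound 1 `CCCCN(c1nc2c(C(=O)NC)cccc2o1)[C@H](C)c1ccc(-c2ccccc2-c2nnn[nH]2)cc1` and compound 2 `CCCCN(c1nc2c(NC(C)=O)cccc2o1)[C@H](C)c1ccc(-c2ccccc2-c2nnn[nH]2)cc1` share one core and differ only at one aromatic carbon of the fused six-membered ring. In an ADME assay on the whole organism (Macaca fascicularis) for metabolic stability, read by LC-MS, using cassette dosing, at a dose of 1 mg/kg by the oral route (on this read-out higher numbers stand for a longer-lived compound and lower numbers for a shorter-lived compound), compound 1 gives 1.3 h, and compound 2 gives 2.2 h. Going by the values given here, the single measured step, a 1.7-fold higher number from compound 1 to compound 2 (0.23 log units; within the scatter), is the only point of comparison, and it is within the scatter, so compound 2 stands at the higher of two numbers without a separation that counts. Compound 3 `CCCCN(c1nc2c(-c3ccccn3)cccc2o1)[C@H](C)c1ccc(-c2ccccc2-c2nnn[nH]2)cc1` is the next member: pyridin-2-yl in place of acetamido on an aromatic carbon. Among the compounds with values here, no measured step covers an aromatic ring entering at this position, so the step from compound 1 to compound 2 is the only guide, and it showed no change beyond the scatter. For compound 3 the number in this assay is therefore expected to stay near that of compound 2, with an expected step of a 1.1-fold lower number from compound 2 to compound 3 (0.04 log units; within the scatter); the estimate for compound 3 is 2 h, within 0.8 h to 5 h.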

Compound 3, half-life: 5.9 h
The estimate for compound 3 lay 3.0-fold (0.47 log units) below the measured number; the measured number lies above the stated range.
By their numbers in this assay, from the lowest: compounds 1 and 2 (each within the scatter of the next); then compound 3.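

In this assay this aromatic carbon now shows a separation: pyridin-2-yl in place of acetamido gives a 2.7-fold higher number from compound 2 to compound 3 (0.43 log units; beyond the scatter) and pyridin-2-yl in place of methylcarbamoyl gives a 4.5-fold higher number from compound 1 to compound 3 (0.66 log units; beyond the scatter) while acetamido and methylcarbamoyl remain within the scatter of each other. The read-out therefore responds to the group carried at this position, and pyridin-2-yl, the only aromatic ring among the three groups, stands apart from both others. No available measurement bears on why the number rises.

From the compounds shown here alone, whether the rise depends on the ring nitrogen stays open, and a plain phenyl or a pyridin-3-yl at this carbon would address that. Also open, going by these compounds, is how a small group such as a nitrile or an amine at this carbon compares with these three groups.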